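The source may report more compounds than this note shows. Statements on the series, on what has been measured and on what is new or still open speak of the compounds shown alone.

In a functional assay on HCT-116 cells (Homo sapiens) for antiproliferative activity, read by MTT assay, with a stated time of 48 h (a lower number here means a stronger inhibitor, a higher number a weaker inhibitor), compound 1 `CCCCCC(CCO)n1cnc2c(NC)ncnc21` returns > 50000 nM, which is a limit of the assay and not a number. Compound 2 `CCCCCCCCC(CCO)n1cnc2c(Cl)ncnc21` gives 1650 nM. Compound 3 `C=C(CO)C(CCCCCCCC)n1cnc2c(Cl)ncnc21` gives 19400 nM, the higher of the two actual numbers, with a 12-fold higher number from compound 2 to compound 3 (1.07 log units; beyond the scatter). Compound 4 `C=C(CO)C(CCCCCCCCC)n1cnc2c(Cl)ncnc21` differs from compound 3 by methyl in place of hydrogen on a saturated chain carbon, nine bonds along the chain from an aromatic nitrogen and a double-bonded chain carbon. Among the measured compounds shown here, the one measured step, a 12-fold higher number from compound 2 to compound 3 (1.07 log units; beyond the scatter), is large but changes a different group, and no measured step alters this chain, so it bears only indirectly. No shift beyond the scatter is therefore expected in this assay, and the expected step is a 1.1-fold lower number from compound 3 to compound 4 (0.06 log units; within the scatter). For compound 4 the estimated value is 17000 nM, with an expected range of 7000 nM to 40000 nM.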

Compound 4, half-maximal inhibitory concentration: > 50000 nM
Compound 4: a limit, no number; the forecaster's own chance of this, stated with the estimate: 10%; at least 2.9-fold (0.46 log units) between middle value and limit.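

Compound 2 to compound 3 changed only the 2-hydroxyethyl group, whereas this result shows that the octyl-type chain itself matters in this assay: methyl in place of hydrogen on a saturated chain carbon, nine bonds along the chain from an aromatic nitrogen and a double-bonded chain carbon, gives an at least 2.5-fold higher number from compound 3 to compound 4 (0.41 log units; beyond the scatter). Compound 4 gives > 50000 nM, which is a limit and not a number. The true size of the step remains unknown, since this value sits at the assay's ceiling: the limit of > 50000 nM in this assay, at which 2 of the 4 values shown sit.

From the compounds shown here alone, whether a shorter chain would lower the number remains open. So does whether a longer chain, or an amine or carboxylic acid on it, would behave alike with the 2-hydroxyethyl group of compound 2.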